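This account rests on a few compounds, and the source may have more. Where it says the series, first, only, none or still open, it means among the compounds named here.

Measured compounds:
compound 1 `Cn1c(/C=C2\SC(=O)N(CC(=O)N3CCOCC3)C2=O)nc2ccccc21`: > 50000 nM
compound 2 `CC(C)n1c(/C=C2\SC(=O)N(CC(=O)N3CCOCC3)C2=O)nc2ccccc21`: > 50000 nM
compound 3 `COc1cc2c(cc1OC)CN(C(=O)CN1C(=O)S/C(=C\c3nc4ccccc4n3C(C)C)C1=O)CC2`: 30600 nM

The three measured compounds were tested in a functional assay on MDA-MB-231 cells (Homo sapiens) for inhibition, read by MTT assay, with a stated time of 48 h; on this read-out higher numbers stand for weaker inhibition and lower numbers for stronger inhibition. In this assay compound 1 reaches only a limit, > 50000 nM, and not a number. Compound 2 likewise gives only a limit, > 50000 nM. The step between them, a step that the two limits leave unreadable from compound 2 to compound 1, therefore cannot be read; the change itself is methyl in place of isopropyl on an aromatic nitrogen. Within the data shown here, compound 3 is the one compound with a number, 30600 nM. How the core of compound 3 differs from the core of compound 2 is not broken down here.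

Compound 4 `COc1cc2c(cc1OC)CN(C(=O)CN1C(=O)S/C(=C\c3nc4ccccc4n3C)C1=O)CC2` has not yet been measured in this assay. Among the measured compounds shown here, it differs from compound 3 by methyl in place of isopropyl on an aromatic nitrogen, which is the same change as the one from compound 2 to compound 1, since the place around it reads the same in both.

That earlier step gives no readable size because of the limit of > 50000 nM in this assay, at which 2 of the 3 values shown sit, so no size can be carried over to compound 4. The expectation for compound 4 rests only on compound 3 and its value 30600 nM: compound 4 is estimated to stay near it, with a step of a 1.3-fold higher number from compound 3 to compound 4 (0.12 log units; within the scatter), and compound 4 is expected to give about 40000 nM, between 12000 nM and 130000 nM. It is also quite possible that compound 4 returns only a limit.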

Compound 4, half-maximal inhibitory concentration: 36000 nM
Compound 4: middle estimate off by 1.1-fold (0.05 log units), on the high side; low and high end bracket the measured number.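

The change of isopropyl to methyl on the aromatic nitrogen gives a 1.2-fold higher number from compound 3 to compound 4 (0.07 log units; within the scatter) in this assay and so stays within the scatter on the core of compound 3. Among these compounds, on the core of compound 2, where both partners give only a limit, the same change has no step that can be read, and the comparison between the two cores cannot go further: the limit of > 50000 nM in this assay, at which 2 of the 4 values shown sit.

The result therefore describes this change on one core only and does not show that it behaves alike on the other core, or that the two steps would agree in size once both could be read.

The compounds shown leave open what a longer chain on the same aromatic nitrogen, such as n-butyl, or a chain ending in an amine or a carboxylic acid, would do to the number on the core of compound 3. Among the compounds shown here, with only methyl and isopropyl at this place, and only two cores carrying them, they also leave open whether any group at this nitrogen can bring a step beyond the scatter.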